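The compounds below may be only part of what the source reports. "The series", "measured", "known", "first", "only" and "open" are said of these compounds alone.

In a functional assay on A498 cells (Homo sapiens) for inhibition, read by sulforhodamine B assay, with a stated time of 48 h, tested at 10 uM (a lower number here means less inhibition of growth, a higher number more inhibition of growth at the concentration tested), compound 1 `COc1ccc(-c2nc3sc(-c4ccccc4)cn3n2)cc1` gives 56%, the higher of the two numbers available. Compound 2 `COc1cc(-c2nc3sc(-c4ccccc4)cn3n2)cc(OC)c1OC` gives 29%, a gap beyond the scatter. Compound 3 `c1ccc(-c2nc3sc(-c4ccccc4)cn3n2)cc1` has not yet been measured. It differs from compound 1 by hydrogen in place of methoxy on an aromatic carbon, with hydrogen in place of methoxy on an aromatic carbon, para to a large group. Going by the values given here, no measured pair isolates this change, so only a modest downward step in this assay is expected, and one within the scatter would be no surprise. The expected change is a number 11 percentage points lower from compound 1 to compound 3 (beyond the scatter). Compound 3 is estimated to give 45%, with an expected range of 25% to 62%.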

Compound 3, percent growth inhibition at one concentration: 13%
For compound 3 the middle estimate is 32 percentage points above the measured one; measured number below the stated range.
By their numbers in this assay, from the lowest: compound 3; then compound 2; then compound 1.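

In this assay, the methoxy para to a large group turns out to matter: hydrogen in its place gives a number 43 percentage points lower from compound 1 to compound 3 (beyond the scatter). Going by these compounds alone, this is the first change at a single place that can be read, and it shows that this position is not indifferent to what sits on it. Nothing at hand explains the size of this step.

The compounds shown do not tell whether any other group at this place, such as a hydroxyl, an ethoxy or an amine, would keep the inhibition. They also leave open whether a methoxy elsewhere on this ring would do the same.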